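A few compounds are considered here, and "the series" means these few. Any claim that something is new, unique, unknown or untested is made for them only; others in the source may bear on it.

Working notes on a small set of compounds. Within the data shown here, compound 1 `c1ccc(COC[C@H]2OCC[C@@H](OCc3ccccc3)[C@@H]2OCc2ccccc2)cc1` is the only member with a number in a functional assay on HL-60 cells (Homo sapiens) for antiproliferative activity, read by MTT assay; on this read-out lower numbers stand for stronger inhibition and higher numbers for weaker inhibition: compound 1 gives 39300 nM. Among the measured compounds shown here, compound 2 `CC(=O)OC[C@@H]1O[C@H](COCc2ccccc2)[C@@H](OCc2ccccc2)[C@H](OCc2ccccc2)[C@H]1OC(C)=O` is reported in this assay as "not active" (no number reported), and compound 3 `CCC[C@@H]1O[C@H](COC)[C@@H](OC)[C@H](OC)[C@H]1O` likewise as "not active" (no number reported); neither carries a number, so no step between measured compounds can be drawn. Compound 4 `O[C@H]1CO[C@H](COCc2ccccc2)[C@@H](OCc2ccccc2)[C@@H]1OCc1ccccc1` is not yet measured. It differs from compound 1 in one place: hydroxy in place of hydrogen on a saturated ring carbon. For the measured compounds named here, with no measured step to lean on, the change is expected to move this assay little, in no firm direction, and the estimated step is a 1.1-fold lower number from compound 1 to compound 4 (0.05 log units; within the scatter), within the usual scatter. Compound 4 is therefore estimated at 35000 nM, with a range from 12000 nM to 100000 nM.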

Compound 4, half-maximal inhibitory concentration: "not active" (no number reported)
Compound 4: no number reported, and the estimate cannot be compared.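

Among these compounds, compound 4 carries no number, so no step from compound 1 can be read, and no available evidence bears on this result. The compounds shown leave open how far hydroxy in place of hydrogen on that saturated ring carbon shifts the activity of compound 1.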